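From Isopropyl to Methoxy at the Assay Limit

The compounds below may be only part of what the source reports. "The series", "measured", "known", "first", "only" and "open" are said of these compounds alone.

Compound 1 `CC(C)c1ccc(C(Nc2ccc(C3(C)NC(=O)c4ccccc4N3)cc2)c2nnnn2C2CCCCC2)cc1` and compound 2 `CC(C)c1ccc(C(Nc2ccc(C3(C)NC(=O)c4ccccc4N3)cc2)c2nnnn2C(C)(C)C)cc1` share one core and differ in the group on an aromatic nitrogen. In an ADME assay on J774.A1 cells (Mus musculus) for cytotoxicity, read by MTT assay, with a stated time of 72 h (on this read-out lower numbers stand for higher toxicity in this test and higher numbers for lower toxicity in this test), compound 1 gives > 400000 nM, which is a limit and not a number. In this assay compound 2 gives > 400000 nM, again a limit. Compound 2 therefore stands at the limit of > 400000 nM in this assay, at which 2 of the 2 values shown sit. Going by the values given here, the only measured step is a step that the two limits leave unreadable from compound 1 to compound 2, so it offers no size to carry over, and it lies at a different place in the structure. Compound 3 `COc1ccc(C(Nc2ccc(C3(C)NC(=O)c4ccccc4N3)cc2)c2nnnn2C(C)(C)C)cc1` keeps the tert-butyl of compound 2 and changes one group: methoxy in place of isopropyl on an aromatic carbon. In words, methoxy replaces isopropyl on an aromatic carbon, para to a large group. With no size to go on, no step beyond the scatter is expected in this assay, and no direction can be given. The estimated step is a number no higher from compound 2 to compound 3 (the limit leaves the size open). For compound 3 the expected value is 400000 nM, within an estimated range of 180000 nM to 800000 nM.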

Compound 3, half-maximal cytotoxic concentration: > 400000 nM
Compound 3 gave a limit, no number; the forecaster's own chance of this, stated with the estimate: 70%; the middle value sits exactly at the limit.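

Compound 3 gives > 400000 nM in this assay, which is a limit and not a number, so no step can be read between compound 2 and compound 3. The compounds shown leave open whether methoxy in place of isopropyl changes toxicity to these cells at all.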